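This account rests on a few compounds, and the source may have more. Where it says the series, first, only, none or still open, it means among the compounds named here.

Three compounds have been measured in an in vitro ADME assay on microsomes from liver (Homo sapiens) for metabolic stability, read by LC-MS; a higher number here means that the compound lasts longer, a lower number that the compound disappears faster:

Compound 1 `Cc1ccc(NC(=O)N2CCCN(C(=O)CCC3CCCC3)CC2)cc1`, in this assay: 0.0667 h
Compound 2 `CCc1ccc(NC(=O)N2CCCN(C(=O)CCC3CCCC3)CC2)cc1`, in this assay: 0.0833 h
Compound 3 `CC(C)(C)c1ccc(NC(=O)N2CCCN(C(=O)CC3CCCC3)CC2)cc1`, in this assay: 0.05 h

Compound 3 gives the smallest of the three numbers, yet its distances to compound 1 and to compound 2 both lie within the scatter, so the three cannot be told apart. Going by the values given here, the only single step among them, a 1.2-fold higher number from compound 1 to compound 2 (0.10 log units; within the scatter), also stays within the scatter. Compound 4 `CC(C)CCC(=O)N1CCCN(C(=O)Nc2ccc(C(C)(C)C)cc2)CC1` differs from compound 3 by isobutyl in place of cyclopentyl on a saturated chain carbon bound to a carbonyl carbon. Among the compounds with values here, no measured step touches that place; the step from compound 1 to compound 2 sits elsewhere and was itself within the scatter, so nothing here points to a shift beyond the scatter in this assay. Compound 4 is therefore expected to give 0.05 h (range 0.02 h to 0.12 h), an expected step of no change at the digits printed from compound 3 to compound 4 (within the scatter).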

Compound 4, half-life: 0.05 h
Compound 4: the middle estimate sits on the measured number at the digits printed; the measured number falls inside the stated range.
By their numbers in this assay, from the lowest: compounds 3, 4, 1 and 2 (each within the scatter of the next).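

In this assay, going by these compounds alone, isobutyl in place of cyclopentyl on a saturated chain carbon bound to a carbonyl carbon gives no change at the digits printed from compound 3 to compound 4 (within the scatter) and is the first measured step at this place. For this pair, then, exchanging the five-membered ring for a branched chain without a ring leaves the half-life within the scatter. Nothing available here accounts for this result. Going by these compounds, whether an amine or a carboxylic acid at this place would move the half-life beyond the scatter stays open. So does whether a longer chain would do so.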